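This account rests on a few compounds, and the source may have more. Where it says the series, first, only, none or still open, it means among the compounds named here.

Of the compounds shown here, two from this study have been tested in a functional assay on SW-620 cells (Homo sapiens) for inhibition, read by MTT assay, with a stated time of 72 h; on this read-out lower numbers stand for stronger inhibition and higher numbers for weaker inhibition. Compound 1, with the structure `COc1ccc(CCCNCc2c(OC)cc(Oc3ccc(Nc4ccccc4)cc3)cc2OC)cc1`, gives in this assay a value of 14600 nM. Compound 2, with the structure `COc1cc(Oc2cccc(Nc3ccccc3)c2)cc(OC)c1CNC1CC1`, is a different matter. In this assay compound 2 gives > 20000 nM, which is a limit of the assay and not a measured number. Compound 2 therefore stands at the limit of > 20000 nM in this assay, at which 1 of the 2 values shown sits, so no exact potency is known for it, only that it lies beyond what the assay could resolve.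

The next compound, compound 3, has the structure `COc1cc(Oc2cccc(Nc3ccccc3)c2)cc(OC)c1CNCc1ccccc1`. It differs from compound 2 in one place: benzyl in place of cyclopropyl on an amine nitrogen. Within the data shown here, no measured pair in this study shows what such a change does in this assay, so its effect cannot be read from the data at hand. With compound 2 already at a limit, a step of any clear size in either direction would be a guess, and the expectation is for a change of an at least 1.1-fold lower number from compound 2 to compound 3 (0.04 log units; that floor lies within the scatter), that is, none beyond the scatter. Compound 3 is thus estimated at 18000 nM, within a range from 6000 nM to 60000 nM.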

Compound 3, half-maximal inhibitory concentration: 7490 nM
Compound 3: middle estimate off by 2.4-fold (0.38 log units), on the high side; measured number inside the range.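

In this assay, among these compounds, putting benzyl in place of cyclopropyl on the amine nitrogen gives an at least 2.6-fold lower number from compound 2 to compound 3 (0.42 log units; beyond the scatter), the first readable change at this position. This shows that the group on this nitrogen matters: with the rest of the molecule unchanged, exchanging this one group moves the number beyond the usual scatter, and the benzyl compound has the lower number. The true size of the step remains unknown, and it can be given only as a minimum because compound 2 has a limit of the assay and not a measured number: the limit of > 20000 nM in this assay, at which 1 of the 3 values shown sits.

This single pair cannot separate the effect of the six-membered aromatic ring from that of the larger group as a whole, since the two differ in both ring type and heavy-atom count. A cyclohexylmethyl group on the same nitrogen would keep a six-membered ring without aromaticity and so bear on the first question, while a phenethyl group would show whether moving the aromatic ring further from the nitrogen keeps, strengthens or weakens the inhibition.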